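The source may hold more compounds than are shown below. What is called first, only, known or untested is meant among the compounds shown, and "the series" means these compounds.

Measured compounds in a functional assay on HT-29 cells (Homo sapiens) for inhibition, read by CCK-8 assay, with a stated time of 24 h; on this read-out higher numbers stand for weaker inhibition and lower numbers for stronger inhibition:

Compound 1 `O=C1Nc2ccccc2/C1=C/c1ccc(-c2cn(-c3cccc(F)c3)nn2)cc1`: in this assay compound 1 gives > 20000 nM, a limit of the assay.
Compound 2 `O=C1Nc2ccccc2/C1=C/c1ccc(-c2cn(-c3ccc(F)cc3)nn2)cc1`: in this assay compound 2 gives 17700 nM.
Compound 3 `O=C1Nc2ccc(F)cc2/C1=C/c1ccc(-c2cn(-c3cccc(F)c3)nn2)cc1`: in this assay compound 3 gives > 12900 nM, a limit of the assay.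

The change from compound 1 to compound 2 is 4-fluorophenyl in place of 3-fluorophenyl on an aromatic nitrogen and gave an at least 1.1-fold lower number from compound 1 to compound 2 (0.05 log units; that floor lies within the scatter); the floor of that step is set by the limit of > 20000 nM in this assay, at which 1 of the 3 values shown sits. The cores of compound 1 and compound 3 differ by fluoro in place of hydrogen on an aromatic carbon, a step that the two limits leave unreadable from compound 1 to compound 3, both limits the limit of > 12900 nM in this assay, at which 1 of the 3 values shown sits, and the limit of > 20000 nM in this assay, at which 1 of the 3 values shown sits, leaving its size open.

Compound 4 `O=C1Nc2ccc(F)cc2/C1=C/c1ccc(-c2cn(-c3ccc(F)cc3)nn2)cc1` is not yet measured. It differs from compound 3 by 4-fluorophenyl in place of 3-fluorophenyl on an aromatic nitrogen, the same change as from compound 1 to compound 2, at a place described in identical words. In this assay the step from compound 3 to compound 4 is expected to be a step that the limit leaves unreadable from compound 3 to compound 4, resting on the near-flat step an at least 1.1-fold lower number from compound 1 to compound 2 (0.05 log units; that floor lies within the scatter) and on compound 3 sitting at a limit, > 12900 nM. Compound 4 is thus estimated at 18000 nM, with a range from 9000 nM to 40000 nM, and a limit rather than a number remains likely.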

Compound 4, half-maximal inhibitory concentration: 20000 nM
Compound 4: middle estimate off by 1.1-fold (0.05 log units), on the low side, within the range that was stated.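

In this assay the step from 3-fluorophenyl to 4-fluorophenyl on the core of compound 3 cannot be read, so carrying this change over from the core of compound 1 cannot be judged in size: the limit of > 12900 nM in this assay, at which 1 of the 4 values shown sits.

Within the data shown here, the one readable new step, fluoro in place of hydrogen on an aromatic carbon with 4-fluorophenyl kept, is a 1.1-fold higher number from compound 2 to compound 4 (0.05 log units; within the scatter). Among these compounds, this shows only that the fluoro change does not separate this pair beyond the scatter, not that the 4-fluorophenyl change has the same effect on both cores.

Open, from the compounds shown here alone, is whether an amine or a carboxylic acid on the phenyl ring at the aromatic nitrogen would move the number in this assay. Also open, going by these compounds, is what a longer chain in place of that ring would do.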